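The source may report more compounds than this note shows. Statements on the series, on what has been measured and on what is new or still open speak of the compounds shown alone.

Series notes. Compound 1 `Cn1cc(NC(=O)c2cccc(NS(=O)(=O)c3ccccc3)c2)cn1` and compound 3 `Cn1cc(NC(=O)c2ccc(NS(=O)(=O)c3ccccc3)cc2)cn1` are built from the same atoms joined differently; the difference between the two cores is not broken down here. In a functional assay on MCF7 cells (Homo sapiens) for inhibition, read by MTT assay, with a stated time of 48 h (a higher number here means a weaker inhibitor, a lower number a stronger inhibitor), compound 1 gives 41200 nM and compound 3 gives 58700 nM; these two values sit within the scatter of each other, so no order between them is claimed. Within the data shown here, compound 2 `O=C(Nc1cnn(-c2ccccc2)c1)c1cccc(NS(=O)(=O)c2ccccc2)c1` carries the change phenyl in place of methyl on an aromatic nitrogen relative to compound 1, and in this assay compound 2 gives 4320 nM; the step of a 9.5-fold lower number from compound 1 to compound 2 (0.98 log units; beyond the scatter) is beyond the scatter and is the only measured instance of this change.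

Compound 4 `O=C(Nc1cnn(-c2ccccc2)c1)c1ccc(NS(=O)(=O)c2ccccc2)cc1` is not yet measured. Against compound 3 it shows (phenyl in place of methyl on an aromatic nitrogen), the same change as that from compound 1 to compound 2, made on a core that differs only in how the same atoms are joined. Among the measured compounds shown here, because the step of a 9.5-fold lower number from compound 1 to compound 2 (0.98 log units; beyond the scatter) came from the one measured pair that shares this change, the expected step for compound 4 is of a similar size, that is a 9.5-fold lower number from compound 3 to compound 4 (0.98 log units; beyond the scatter) in this assay. On that basis compound 4 is estimated at 6200 nM in this assay, with a plausible range from 2500 nM to 16000 nM; the width allows for the change being carried over from a single pair on a differently joined core.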

Compound 4, half-maximal inhibitory concentration: 17100 nM
Compound 4: the middle estimate sits 2.8-fold (0.44 log units) below what was measured; measured number outside the range, above it.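

In this assay, phenyl in place of methyl on an aromatic nitrogen lowers the number on the second core as well (a 3.4-fold lower number from compound 3 to compound 4 (0.54 log units; beyond the scatter)), so the direction of the change is the same in both measured pairs. Two pairs do not show which feature of the two cores goes with the difference in size, nor how large the step would be on a third core, and they establish no general rule for the series. The direction therefore carries from one core to the other in these two pairs, but the size of the step does not carry over unchanged: the same change on two cores in this assay, a 9.5-fold lower number (0.98 log units; beyond the scatter) from compound 1 to compound 2 and a 3.4-fold lower number (0.54 log units; beyond the scatter) from compound 3 to compound 4, 2.8-fold (0.44 log units) apart, beyond the scatter of two such steps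

The compounds shown leave open how the number responds on either core to other groups on that aromatic nitrogen, such as a longer chain, a benzyl group or a chain ending in an amine, and so whether the difference between the two steps persists beyond phenyl and methyl. They also leave open what a carboxylic acid or a halogen on the phenyl of the sulfonyl group would do, and whether the two steps keep their sizes in other cell lines or at other exposure times.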